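The source may hold more compounds than are shown below. What is called first, only, known or untested is meant among the compounds shown, and "the series" means these compounds.

Working notes on the naphthyloxy acylhydrazone series in an ADME assay on HEL cells (Homo sapiens) for cytotoxicity; on this read-out higher numbers stand for lower toxicity in this test and lower numbers for higher toxicity in this test.

Three compounds share the core and differ only in the aryl group on the carbon with a double bond to nitrogen. Compound 1 `O=C(COc1cccc2ccccc12)N/N=C/c1ccccc1O` carries a 2-hydroxyphenyl there and gives 20 ug/mL. Compound 2 `O=C(COc1cccc2ccccc12)N/N=C/c1ccccc1` carries an unsubstituted phenyl and gives 100 ug/mL. Compound 3 `O=C(COc1cccc2ccccc12)N/N=C/c1ccc(F)cc1` carries a 4-fluorophenyl and gives 100 ug/mL. The steps run a 5.0-fold higher number from compound 1 to compound 2 (0.70 log units; beyond the scatter) and a 5.0-fold higher number from compound 1 to compound 3 (0.70 log units; beyond the scatter), while no change at the digits printed from compound 2 to compound 3 (within the scatter). Compound 3 thus stands level with compound 2 at the digits shown, the two together at the high end of the three numbers, with compound 1 the furthest away.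

The next compound, compound 4 `O=C(COc1cccc2ccccc12)N/N=C/c1cccc(Cl)c1`, differs from compound 3 by 3-chlorophenyl in place of 4-fluorophenyl on a carbon with a double bond to nitrogen. For the measured compounds named here, the only measured step that touches a halogen on this ring is the one from compound 2 to compound 3, which stayed within the scatter; no measured step moves a substituent around the ring or exchanges fluorine for chlorine. On that basis the step of no change at the digits printed from compound 3 to compound 4 (within the scatter) is expected to stay within the scatter. For compound 4 the expected value in this assay is 100 ug/mL, with a range of 50 ug/mL to 200 ug/mL.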

Compound 4, minimum cytotoxic concentration: 100 ug/mL
For compound 4 middle estimate and measured number coincide at the digits printed; low and high end bracket the measured number.
By their numbers in this assay, from the lowest: compound 1; then compounds 2, 3 and 4 (each within the scatter of the next).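

Read in this assay the exchange of 4-fluorophenyl for 3-chlorophenyl on the carbon with a double bond to nitrogen gives a flat step (no change at the digits printed from compound 3 to compound 4 (within the scatter)), and setting 3-chlorophenyl against the unsubstituted phenyl gives another (no change at the digits printed from compound 2 to compound 4 (within the scatter)). Where the earlier compounds offered only fluoro on this ring, a second halogen, in a different ring place, now also stays within the scatter of the unsubstituted phenyl. For the compounds shown here, the 2-hydroxyphenyl group remains the only aryl group in these four compounds that stands apart, with a third step of the same size as the earlier two (a 5.0-fold higher number from compound 1 to compound 4 (0.70 log units; beyond the scatter)), and no compound here goes against that; nothing on hand accounts for either the flat steps or that gap.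

Open, from the compounds shown here alone, is whether the gap belongs to the hydroxy group itself or to its place on the ring, which 3-hydroxyphenyl, 4-hydroxyphenyl or 2-methoxyphenyl would address. Also open, going by these compounds, is how this aryl position responds to groups of another kind, such as an amine or a carboxylic acid on the ring.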